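The source may report more compounds than this note shows. Statements on the series, on what has been measured and on what is new or still open speak of the compounds shown alone.

Working notes on the series. Compound 1 `CCN(C)C(=O)/C=C1\CCc2c(F)cc(F)cc21` gives 100% in a functional assay on the whole organism with Mus musculus as the target, at a dose of 100 mg/kg by the intraperitoneal route; on this read-out lower numbers stand for less inhibition and higher numbers for more inhibition at the one dose given (going by the name of the read-out). Compound 2 `NC(=O)/C=C1/CCc2ccc(F)cc21` gives 100% and compound 3 `NC(=O)/C=C1\CCc2cc(F)c(F)cc21` gives 100%, so compound 1 stands level with both at the digits shown, with no change beyond the scatter toward either. Compound 4 `CC(C)NC(=O)/C=C1\CCc2c(F)cc(F)cc21` has not been measured in this assay. Against compound 1 the difference is isopropylamino in place of ethyl(methyl)amino on a carbonyl carbon. Within the data shown here, no step between measured compounds covers this change, so its size is untested here. All three measured compounds sit at the top of the read-out. Compound 4 is expected to stay near that level, the step of a number 5 percentage points lower from compound 1 to compound 4 (within the scatter) being expected to be none beyond the scatter. The value of compound 4 in this assay is estimated at 95%, within 70% to 100%.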

Compound 4, a percentage reported as inhibition, in the whole organism at one dose (the size of the read-out at that dose, not a potency): 100%
The estimate for compound 4 lay 5 percentage points below the measured number; measured number inside the range.
By their numbers in this assay, from the lowest: compounds 1, 2, 3 and 4 (each within the scatter of the next).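

On the carbonyl carbon, isopropylamino in place of ethyl(methyl)amino, which adds the amide hydrogen, gives no change at the digits printed from compound 1 to compound 4 (within the scatter) in this assay. The change of amine on this carbonyl carbon therefore costs nothing visible at this dose, but all the compounds shown sit at the top of the read-out, so any gain would go unseen. No measured evidence bears on this flat step. From the compounds shown here alone, whether a carboxylic acid or a longer chain in place of the amine holds this level remains open. Going by these compounds, how these amides compare at lower doses also remains open.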